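Three Chains, One Value: What Compound 4 May Show

This account rests on a few compounds, and the source may have more. Where it says the series, first, only, none or still open, it means among the compounds named here.

In a functional assay on MDA-MB-231 cells (Homo sapiens) for antiproliferative activity, read by MTT assay (a higher number here means a weaker inhibitor, a lower number a stronger inhibitor), compound 3 `CC/C=C\C/C=C\C/C=C\CCCCCCCc1cc(=O)c2c(O)c(C)c(O)c(C)c2o1` gives 6790 nM. It stands level with its two measured relatives. The long chain of compound 3 stands on a different core in compound 2 `CC/C=C\C/C=C\C/C=C\CCCCCCCc1cc(=O)c2c(O)cc(O)cc2o1`, which gives 6790 nM. Compound 1 `CCCC/C=C\CCCCCCCCCc1cc(=O)c2c(O)cc(O)c(C)c2o1`, which has a different chain and core, gives 6790 nM.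

Compound 4 `CCCC/C=C\CCCCCCCCCc1cc(=O)c2c(O)c(C)c(O)c(C)c2o1` keeps the core of compound 3 and changes only the end of the chain: a group of 8 heavy atoms (8 carbon; no ring) in place of a group of 10 heavy atoms (10 carbon; no ring), on a saturated chain carbon, seven bonds along the chain from an aromatic carbon. The oct-3-en-1-yl group enters on a saturated chain carbon, seven bonds along the chain from an aromatic carbon.

Within the data shown here, no measured pair isolates this change, so the evidence is indirect. The chain of compound 4 already appears in compound 1, and compound 1 gives 6790 nM, the same value as compound 3. No change beyond the scatter is therefore expected, and the estimated step of no change at the digits printed from compound 3 to compound 4 (within the scatter) has no favoured direction. Compound 4 is expected to give about 6790 nM, within an estimated range of 3400 nM to 13500 nM.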

Compound 4, half-maximal inhibitory concentration: > 87000 nM
Compound 4 ended at the assay's limit; the forecaster's own chance of this, stated with the estimate: 10%; middle value at least 12-fold (1.10 log units) away from the limit.
By their numbers in this assay, from the lowest: compounds 1, 2 and 3 (each within the scatter of the next). At a limit, above all of these: compound 4.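

Compound 4 has no exact reading in this assay, only a limit: the limit of > 87000 nM in this assay, at which 1 of the 4 values shown sits. With the core held fixed, changing only the end of the chain gives an at least 12-fold higher number from compound 3 to compound 4 (1.10 log units; beyond the scatter), so at this place on the chain, the oct-3-en-1-yl group and the group of 10 heavy atoms are not interchangeable on this core. With the chain held fixed, methyl in place of hydrogen on an aromatic carbon gives an at least 12-fold higher number from compound 1 to compound 4 (1.10 log units; beyond the scatter), which shows that a single small change to the core can also matter greatly with this chain.

The compounds shown leave open whether a longer chain, a fully saturated chain or a carboxylic acid at the chain end would behave like the chain of compound 3 or that of compound 4 on this core. Going by these compounds, the true value of compound 4 also remains unknown, so the full size of both steps stays open.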